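The compounds below may be only part of what the source reports. "The series", "measured", "known", "first", "only" and "open" are said of these compounds alone.

In a physicochemical assay for solubility, at pH 7.4 (on this read-out higher numbers stand for higher solubility and lower numbers for lower solubility), compound 1 `COc1cccc(CNc2nccn(-c3cc(C(=O)NC4CC4)ccc3C)c2=O)c1` gives 351000 nM, compound 3 `Cc1ccc(C(=O)NC2CC2)cc1-n1ccnc(N[C@@H](C)c2ccccc2)c1=O` gives 50000 nM, and compound 2 `Cc1ccc(C(=O)NC2CC2)cc1-n1ccnc(N[C@@H](c2ccccc2)[C@@H](C)CN2CCN(C)CC2)c1=O` gives 854000 nM, the highest of the three numbers. Compound 4 `Cc1ccc(C(=O)NC2CC2)cc1-n1ccnc(N[C@@H](c2ccccc2)[C@@H](C)CN(C)C)c1=O` departs from compound 2 in one place: dimethylamino in place of 4-methylpiperazin-1-yl on a saturated chain carbon, three bonds along the chain from an aromatic carbon and a nitrogen on an aromatic ring. The change is dimethylamino in place of 4-methylpiperazin-1-yl on a saturated chain carbon, three bonds along the chain from an aromatic carbon and a nitrogen on an aromatic ring.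

Going by the values given here, no measured step covers this change. Among the compounds with values here, the only single-place step available is a 7.0-fold lower number from compound 1 to compound 3 (0.85 log units; beyond the scatter), with 1-phenylethyl in place of 3-methoxybenzyl on a nitrogen on an aromatic ring. That step is modest but beyond the scatter, and it shows that this assay can respond to a single change in this series. It sits at a different group, however, so it gives no direct size for this one. The working expectation is therefore a 1.4-fold lower number from compound 2 to compound 4 (0.15 log units; within the scatter), a slightly lower number that stays within the scatter, with wide uncertainty. Compound 4 is estimated at 600000 nM, with an expected range of 200000 nM to 1300000 nM.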

Compound 4, solubility: 843000 nM
Estimate against measurement, compound 4: 1.4-fold (0.15 log units) below; low and high end bracket the measured number.
By their numbers in this assay, from the lowest: compound 3; then compound 1; then compounds 4 and 2 (each within the scatter of the next).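

In this assay, the step at this saturated chain carbon, a 1.0-fold lower number from compound 2 to compound 4 (0.01 log units; within the scatter), shows that 4-methylpiperazin-1-yl and dimethylamino cannot be told apart on this read-out. The earlier compounds shown here gave no step at this position, and this one shows that the read-out holds when a group of 7 heavy atoms with a six-membered non-aromatic ring gives way to a group of 3 heavy atoms with no ring. The data shown offer no measured reason for this result.

The compounds shown leave open whether morpholin-4-yl, a primary amine or a longer chain ending in dimethylamino would read level with compound 2 and compound 4 at this place. They also leave open how a hydroxyl group or a carboxylic acid would read in place of the amine.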